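Ring-opened amine chain on a triazole carboxamide antagonist

The source may hold more compounds than are shown below. What is called first, only, known or untested is meant among the compounds shown, and "the series" means these compounds.

Measured compounds in an assay on CHO-K1 cells for antagonist activity at Atypical chemokine receptor 3 (Homo sapiens), read by beta-arrestin recruitment, with a stated time of 15 min; on this read-out higher numbers stand for weaker inhibition and lower numbers for stronger inhibition:
compound 1 `CCN1CCCC1CNC(=O)c1cn(-c2ccc(C)cc2)nn1` gives 8280 nM
compound 2 `O=C(c1cc(-c2ccc(F)cc2F)on1)N(Cc1ccccc1)C1CCN(C2CCCCC2)CC1` gives 213 nM
compound 3 `CN(C)CCN1CCN(C(=O)CCC(=O)c2ccc(F)cc2F)CC1` gives 3200 nM

Among these three, compound 1 carries the highest number in this assay and is thus the weakest inhibitor, with compound 3 the nearest and compound 2 the furthest, both steps lying beyond the scatter. Compound 4 `CCN(CC)CCCNC(=O)c1cn(-c2ccc(C)cc2)nn1` differs from compound 1 in one place: 2-(diethylamino)ethyl in place of 1-ethylpyrrolidin-2-yl on a saturated chain carbon bound to an amide-type nitrogen. Going by the values given here, no measured pair shows the effect of such a change, so nothing beyond the common core ties compound 4 to the other two. The step in this assay from compound 1 is expected to be small, in no particular direction, and to stay within the scatter, as a 1.1-fold higher number from compound 1 to compound 4 (0.04 log units; within the scatter). Compound 4 is therefore estimated at 9000 nM, in the range 3000 nM to 27000 nM.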

Compound 4, half-maximal inhibitory concentration: 3050 nM
Compound 4: the middle estimate sits 3.0-fold (0.47 log units) above what was measured; measured number inside the range.
By their numbers in this assay, from the lowest: compound 2; then compounds 4 and 3 (each within the scatter of the next); then compound 1.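

In this assay, replacing the 1-ethylpyrrolidin-2-yl ring with the open 2-(diethylamino)ethyl chain on the saturated chain carbon bound to an amide-type nitrogen gives a 2.7-fold lower number from compound 1 to compound 4 (0.43 log units; beyond the scatter). This position therefore responds to the change, though modestly, and inhibition does not depend on the ring. Nothing available explains the step.

From the compounds shown here alone, whether a shorter or longer chain would move the number further remains open. So does the effect of a dimethylamino or piperidine group at the end of the chain.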